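Methoxy for chloro on the aryl ring of compound 3

The source may hold more compounds than are shown below. What is called first, only, known or untested is meant among the compounds shown, and "the series" means these compounds.

Measured so far:
compound 1, `CN1C[C@@H](c2ccc(F)cc2)[C@@]2(Cc3ccccc3C2=O)[C@@]12C(=O)Nc1ccccc12`, 40.6%;
compound 2, `CN1C[C@@H](c2ccc(Cl)cc2)[C@@]2(Cc3ccccc3C2=O)[C@@]12C(=O)Nc1ccccc12`, 27.9%;
compound 3, `CN1C(=O)[C@@]2(c3ccccc31)N(C)C[C@@H](c1ccc(Cl)cc1)[C@@]21Cc2ccccc2C1=O`, 47.2%.

In a functional assay on the whole organism (strain Wister albino) for inhibition, with Rattus norvegicus as the target, read by paw edema, with a stated time of 1 h, at a dose of 50 mg/kg by the intraperitoneal route (a higher number here means more inhibition at the dose given (going by the name of the read-out), a lower number less inhibition), compound 3 gives the highest of the three numbers; compound 1 sits within the scatter of it, and compound 2 lies a number 19.3 percentage points higher from compound 2 to compound 3 (beyond the scatter). Compound 4, `COc1ccc([C@@H]2CN(C)[C@]3(C(=O)N(C)c4ccccc43)[C@]23Cc2ccccc2C3=O)cc1`, differs from compound 3 by methoxy in place of chloro on an aromatic carbon. Within the data shown here, the only measured step at that position is a number 12.7 percentage points lower from compound 1 to compound 2 (beyond the scatter), a halogen swap of modest size; no measured step covers methoxy, so the direction is uncertain and little change beyond the scatter is expected. Compound 4 is therefore estimated to give 42%, with a range from 25% to 58%, a step of a number 5.2 percentage points lower from compound 3 to compound 4 (within the scatter).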

Compound 4, a percentage reported as inhibition, in the whole organism at one dose (the size of the read-out at that dose, not a potency): 46.9%
For compound 4 the middle estimate is 4.9 percentage points below the measured one, within the range that was stated.
By their numbers in this assay, from the lowest: compound 2; then compounds 1, 4 and 3 (each within the scatter of the next).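

In this assay, replacing 4-chlorophenyl with 4-methoxyphenyl gives a number 0.3 percentage points lower from compound 3 to compound 4 (within the scatter), so with a methyl on the amide-type nitrogen, this position accepts methoxy, which adds a hydrogen-bond acceptor, with no change beyond the scatter. Among these compounds, the only earlier step at this position, a number 12.7 percentage points lower from compound 1 to compound 2 (beyond the scatter), was a halogen swap on compounds bearing the amide hydrogen, and it lay beyond the scatter. Nothing available accounts for this outcome. Going by these compounds, it remains open whether methoxy would give a similar result with the amide hydrogen in place. An amine, a carboxylic acid or a longer chain such as butoxy at this position also remains untested among the compounds shown.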